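Trading a methylphenyl for a second indole on the core

The source may hold more compounds than are shown below. What is called first, only, known or untested is meant among the compounds shown, and "the series" means these compounds.

In a functional assay on HeLa cells (Homo sapiens) for inhibition, read by CCK-8 assay, with a stated time of 48 h (on this read-out higher numbers stand for weaker inhibition and lower numbers for stronger inhibition), compound 3 `COc1cc(-c2ccnc3cc(-c4cccc(C)c4)nn23)cc(OC)c1OC` gives 4230 nM. Within the data shown here, this is the higher of the two true numbers so far, and compound 2 `COc1cc(-c2ccnc3cc(-c4cn(C)c5ccccc45)nn23)cc(OC)c1OC` gives 399 nM. Compound 1 `COc1cc(-c2ccnc3cc(-c4cccc(C#N)c4)nn23)cc(OC)c1OC` gives > 10000 nM, which is a limit of the assay and not a number.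

The next compound, compound 4 `COc1cc(-c2ccnc3cc(-c4ccc5ccn(C)c5c4)nn23)cc(OC)c1OC`, carries 1-methyl-1H-indol-6-yl in place of 3-methylphenyl on an aromatic carbon of the shared core (1-methyl-1H-indol-6-yl in place of 3-methylphenyl on an aromatic carbon). The closest guide is compound 2, which has the related 1-methyl-1H-indol-3-yl group. Replacing that group with 3-methylphenyl gave an 11-fold higher number from compound 2 to compound 3 (1.03 log units; beyond the scatter), a large step. The change away from 3-cyanophenyl points the same way: the indole gave an at least 25-fold lower number from compound 1 to compound 2 (1.39 log units; beyond the scatter), while the methyl swap gave only an at least 2.3-fold lower number from compound 1 to compound 3 (0.37 log units; beyond the scatter).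

Only one indole has been measured on this core, and the group in compound 4 is a different indol-yl, so only part of that gain is expected to carry over. The expected change is a 4.7-fold lower number from compound 3 to compound 4 (0.67 log units; beyond the scatter), towards stronger inhibition. For compound 4 the estimated value is 900 nM, with an expected range of 250 nM to 3500 nM.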

Compound 4, half-maximal inhibitory concentration: 187 nM
Compound 4: middle estimate off by 4.8-fold (0.68 log units), on the high side; measured number below the stated range.
By their numbers in this assay, from the lowest: compound 4; then compound 2; then compound 3. At a limit, above all of these: compound 1.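

In this assay, 1-methyl-1H-indol-6-yl in place of 3-methylphenyl gave a 23-fold lower number from compound 3 to compound 4 (1.35 log units; beyond the scatter), so a large gain at this position is no longer tied to a single indole: it now appears with two different indol-yl groups. The choice of indol-yl group also counts, though less, as 1-methyl-1H-indol-6-yl in place of 1-methyl-1H-indol-3-yl gave a 2.1-fold lower number from compound 2 to compound 4 (0.33 log units; beyond the scatter), a modest step towards stronger inhibition. Against 3-cyanophenyl the change gave an at least 53-fold lower number from compound 1 to compound 4 (1.72 log units; beyond the scatter), and that size is only a floor because compound 1 stands at a limit of the assay: the limit of > 10000 nM in this assay, at which 1 of the 4 values shown sits.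

Both indoles shown carry a methyl on the ring nitrogen, so it remains open whether the gain survives with 1H-indol-6-yl, which has a hydrogen there, or with a longer chain such as ethyl. As far as these compounds go, it is also open whether the gain follows the second ring or the ring nitrogen, a question that an all-carbon naphthyl group at this position could help to separate.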